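Swapping trifluoromethoxy for amino on a urea-linked phenyl ring

This account rests on a few compounds, and the source may have more. Where it says the series, first, only, none or still open, it means among the compounds named here.

Compound 1 `Cc1cc(NC(=O)Nc2ncccc2C)c2ccccc2n1` — 1300 nM
Compound 2 `Cc1cc(NC(=O)Nc2ccc(N)cc2)c2ccccc2n1` — 18500 nM
Compound 3 `Cc1cc(NC(=O)Nc2ccccc2OC(F)(F)F)c2ccccc2n1` — 4600 nM

Three ureas sharing one core have been measured in a physicochemical assay for solubility, at pH 7.4; on this read-out higher numbers stand for higher solubility and lower numbers for lower solubility. Compound 3 stands second highest of the three: its nearest neighbour is compound 1, which gives a lower number, and furthest is compound 2, which gives the highest number of the set. The next compound, compound 4 `Cc1cc(NC(=O)Nc2ccccc2N)c2ccccc2n1`, differs from compound 3 in one place: amino in place of trifluoromethoxy on an aromatic carbon.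

Among the measured compounds shown here, no measured step removes a trifluoromethoxy group, so the only guidance comes from the step of a 14-fold higher number from compound 1 to compound 2 (1.15 log units; beyond the scatter), which introduces an aminophenyl group and produces a large rise in this assay. For the measured compounds named here, compound 2, the only measured compound carrying an amino group, sits highest. On that basis compound 4 is expected to move upward, by about a 3.0-fold higher number from compound 3 to compound 4 (0.48 log units; beyond the scatter), though the different position of the amino group leaves this uncertain. Compound 4 is therefore estimated at 14000 nM, with a range from 5000 nM to 40000 nM.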

Compound 4, solubility: 51800 nM
Compound 4: middle estimate off by 3.7-fold (0.57 log units), on the low side; measured number above the stated range.
By their numbers in this assay, from the lowest: compound 1; then compound 3; then compound 2; then compound 4.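

In this assay, amino in place of trifluoromethoxy on this aromatic carbon, ortho to a large group, gives an 11-fold higher number from compound 3 to compound 4 (1.05 log units; beyond the scatter) as a large change at a single place on the ring. The location of the amino group matters too: 2-aminophenyl in place of 4-aminophenyl gives a 2.8-fold higher number from compound 2 to compound 4 (0.45 log units; beyond the scatter) as a modest step that is still beyond the scatter, while 2-aminophenyl in place of 3-methylpyridin-2-yl gives a 40-fold higher number from compound 1 to compound 4 (1.60 log units; beyond the scatter) and so spans the whole set. Nothing measured here accounts for these rises.

As far as these compounds go, it remains open whether a dimethylamino group, a hydroxyl or a carboxylic acid at this same place would give a number like that of the amino group. From the compounds shown here alone, it is also open whether the amino group would produce a similar rise on a different core.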